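Iodo in Place of Ethynyl on a Methoxy Nucleoside

A few compounds are considered here, and "the series" means these few. Any claim that something is new, unique, unknown or untested is made for them only; others in the source may bear on it.

In a functional assay on HCT-116 cells (Homo sapiens), read by MTT assay, with a stated time of 72 h (on this read-out higher numbers stand for weaker inhibition and lower numbers for stronger inhibition), compound 2 `C#Cc1cn([C@@H]2O[C@H](CO)[C@@H](O)[C@H]2O)c2ncnc(OC)c12` stands on the only number shown: compound 2 gives 4060 nM. Among the measured compounds shown here, the one further value in this assay is not a number but a limit. In this assay compound 1 `CNc1ncnc2c1c(I)cn2[C@@H]1O[C@H](CO)[C@@H](O)[C@H]1O` gives > 100000 nM, which is a limit of the assay. That value is the limit of > 100000 nM in this assay, at which 1 of the 2 values shown sits.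

Compound 3 `COc1ncnc2c1c(I)cn2[C@@H]1O[C@H](CO)[C@@H](O)[C@H]1O` has not yet been measured. It differs from compound 2 by iodo in place of ethynyl on an aromatic carbon. For the measured compounds named here, no step between measured compounds is available for this change, so the account rests on the two values shown and the structural change alone. In this assay the step is expected to be a loss of inhibition beyond the usual scatter, though not a large one, and the expected step is a 3.7-fold higher number from compound 2 to compound 3 (0.57 log units; beyond the scatter). On that footing compound 3 is estimated at 15000 nM in this assay, with a range from 3000 nM to 80000 nM; the measurement will show whether the iodo group holds or forfeits the inhibition seen with ethynyl.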

Compound 3, half-maximal inhibitory concentration: > 20000 nM
Compound 3: a limit, no number; the forecaster's own chance of this, stated with the estimate: 30%; at least 1.3-fold (0.12 log units) between middle value and limit.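

Set on the aromatic carbon two ring bonds from the ring nitrogen, iodo does not hold the inhibition that ethynyl gives on the methoxy core in this assay: the change brings an at least 4.9-fold higher number from compound 2 to compound 3 (0.69 log units; beyond the scatter). Compound 3 gives > 20000 nM, which is a limit of the assay and not a number, so the step has a lower bound but no known upper end. Iodo had so far been seen only with methylamino, in compound 1, and with methoxy it now also gives no number, so among the compounds shown only ethynyl at this place gives one.

The step between compound 1 and compound 3, methoxy in place of methylamino, cannot be read, as both values are limits, and so the compounds shown do not tell how these two groups compare when iodo is present. Also open, on these data alone, is how methylamino would stand with ethynyl at this aromatic carbon, and how a nitrile or a longer chain ending in a triple bond would stand there in place of ethynyl on the methoxy core.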